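The compounds below may be only part of what the source reports. "The series", "measured", "known", "first", "only" and "open" are said of these compounds alone.

Within the data shown here, compound 2 `CCCCCCCCCCCCCCCCO[C@H]1O[C@H](COC[C@H](O)CO)[C@@H](O)[C@H](O)[C@H]1NC(=O)CCCC` has the lower of the two numbers measured so far. In a functional assay on A-375 cells (Homo sapiens), read by thymidine incorporation (a lower number here means a stronger inhibitor, a higher number a weaker inhibitor), compound 2 gives 2.2 uM. Its nearest neighbour is compound 1 `CCCCCCCCCCCCCCCCO[C@H]1O[C@H](COCC(CO)(CO)COS(=O)(=O)O)[C@@H](O)[C@H](O)[C@H]1NC(=O)CCCC`, which in this assay gives 2.3 uM; the step of a 1.0-fold lower number from compound 1 to compound 2 (0.02 log units; within the scatter) is within the scatter, so the two compounds cannot be placed in order.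

Compound 3 `CCCCCCCCCCCCCCCCO[C@H]1O[C@H](COC[C@@H](O)CO)[C@@H](O)[C@H](O)[C@H]1NC(=O)CCCC` differs from compound 2 only in configuration: the two compounds have the same atoms and bonds and differ only in configuration as drawn: 1 of 6 stereo elements differ; a stereocentre at a saturated chain carbon is drawn R in compound 2 and S in compound 3. Among the measured compounds shown here, no measured step speaks to a change of this kind. For the measured compounds named here, the single step on record, a 1.0-fold lower number from compound 1 to compound 2 (0.02 log units; within the scatter), concerns a different change and is itself within the scatter, so there is nothing in these numbers that would point to a step in either direction for compound 3 in this assay.

Compound 3 is therefore expected to stay close to its parent, with the step of a 1.1-fold higher number from compound 2 to compound 3 (0.06 log units; within the scatter) expected to fall within the scatter. For compound 3 in this assay the estimate is 2.5 uM, expected to lie between 0.9 uM and 7 uM.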

Compound 3, concentration for 50% inhibition: 3.4 uM
For compound 3 the middle estimate is 1.4-fold (0.13 log units) below the measured one, and the stated range covers the measured number.
By their numbers in this assay, from the lowest: compounds 2, 1 and 3 (each within the scatter of the next).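

In this assay, among these compounds, the stereocentre at the saturated chain carbon can now be read for the first time: going from R to S gives a 1.5-fold higher number from compound 2 to compound 3 (0.19 log units; within the scatter), so the drawn configuration at this carbon does not set the two compounds apart. This comparison speaks to that stereocentre alone: the fact that compounds 2 and 3 differ only in the configuration as drawn. The replacement of 2-hydroxy-1-(hydroxymethyl)-1-((sulfooxy)methyl)ethyl by 1,2-dihydroxyethyl, now seen with the S form as well, gives a 1.5-fold higher number from compound 1 to compound 3 (0.17 log units; within the scatter), so neither stereochemical form separates from the sulfated side chain.

From the compounds shown here alone, what remains open is whether any group at this position can move the number beyond the scatter. The compounds shown do not tell what an amine or a carboxylic acid in place of the 1,2-dihydroxyethyl group would give in this assay.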